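This account rests on a few compounds, and the source may have more. Where it says the series, first, only, none or still open, it means among the compounds named here.

Compound 1 `CO[C@@H]1[C@@H](O)[C@@H](O)[C@H](Oc2ccc3cc(NC(=O)C4CCCC4)c(=O)oc3c2C)OC1(C)C` gives 67000 nM in a functional assay on SK-BR-3 cells (Homo sapiens) for antiproliferative activity; a lower number here means a stronger inhibitor, a higher number a weaker inhibitor.
Compound 2 `CCC(=O)Nc1cc2ccc(O[C@@H]3OC(C)(C)[C@H](OC)[C@@H](O)[C@H]3O)c(C)c2oc1=O` gives 643000 nM in this assay.
Compound 3 `CO[C@@H]1[C@@H](O)[C@@H](O)[C@H](Oc2ccc3cc(NC(C)=O)c(=O)oc3c2C)OC1(C)C` reaches only > 900000 nM in this assay, a limit of the assay rather than a number.

Of the two numbers actually obtained, compound 1 stands lowest, that is, as the stronger inhibitor. Its nearest neighbour is compound 2, reached by a 9.6-fold higher number from compound 1 to compound 2 (0.98 log units; beyond the scatter). Cutting the same group down further gives an at least 13-fold higher number from compound 1 to compound 3 (1.12 log units; beyond the scatter). Compound 3 sits at the limit of > 900000 nM in this assay, at which 1 of the 3 values shown sits.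

Compound 4 `CO[C@@H]1[C@@H](O)[C@@H](O)[C@H](Oc2ccc3cc(NC(=O)C4CCCCC4)c(=O)oc3c2C)OC1(C)C` differs from compound 1 by cyclohexyl in place of cyclopentyl on a carbonyl carbon. Both measured steps move away from the cyclopentyl group toward smaller groups, ethyl and methyl, and both raise the number. The step to compound 4 runs the other way, toward a cyclohexyl ring, so no worsening of that kind is expected in this assay; a change staying within the scatter, perhaps a slight lowering, is the expectation. Compound 4 is therefore expected to give about 50000 nM, within 18000 nM to 140000 nM. The expected step is a 1.3-fold lower number from compound 1 to compound 4 (0.13 log units; within the scatter).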

Compound 4, half-maximal inhibitory concentration: 46800 nM
Compound 4: middle estimate off by 1.1-fold (0.03 log units), on the high side; low and high end bracket the measured number.
By their numbers in this assay, from the lowest: compounds 4 and 1 (each within the scatter of the next); then compound 2. At a limit, above all of these: compound 3.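

In this assay, cyclohexyl in place of cyclopentyl on the carbonyl carbon gives a 1.4-fold lower number from compound 1 to compound 4 (0.16 log units; within the scatter), so this position accepts a ring one carbon larger and the data do not separate the two rings. The earlier compounds shown here showed the advantage of cyclopentyl over the ethyl and methyl groups, and cyclohexyl now shows the same kind of gap, with a 14-fold lower number from compound 2 to compound 4 (1.14 log units; beyond the scatter) and an at least 19-fold lower number from compound 3 to compound 4 (1.28 log units; beyond the scatter), so the advantage is not unique to the five-membered ring. The second of these steps is only a floor, as compound 3 has a limit of the assay rather than a number: the limit of > 900000 nM in this assay, at which 1 of the 4 values shown sits.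

From the compounds shown here alone, whether a longer open chain, such as hexyl, would match these two rings remains open. So does the effect of a larger cycloheptyl ring, a flat phenyl ring, or a ring carrying an amine or a carboxylic acid.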